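The source may hold more compounds than are shown below. What is called first, only, known or untested is meant among the compounds shown, and "the series" means these compounds.

The series shares one core, seen in compound 1 `COc1ccccc1-c1ccc(S(=O)(=O)N2CCC(N3CCC(C)CC3)CC2)cc1`, compound 2 `CC1CCN(C2CCN(S(=O)(=O)c3ccc(-c4ccccc4F)cc3)CC2)CC1` and compound 3 `CCc1ccc(S(=O)(=O)N2CCC(N3CCC(C)CC3)CC2)cc1`. In a functional assay on DLD-1 cells (Homo sapiens) for antiproliferative activity, read by CellTiter-Glo, with a stated time of 72 h (a higher number here means a weaker inhibitor, a lower number a stronger inhibitor), compound 1 gives 26 nM and compound 2 gives 5 nM. For compound 3 this assay reports only a limit, > 5000 nM. For the measured compounds named here, compound 3 stands at the limit of > 5000 nM in this assay, at which 1 of the 3 values shown sits, and is the one member of the three for which no number is known. The step under review runs from compound 3 to compound 4 `COc1ccc(-c2ccc(S(=O)(=O)N3CCC(N4CCC(C)CC4)CC3)cc2)cc1`: 4-methoxyphenyl in place of ethyl on an aromatic carbon. The measured steps that bear on it run the other way: replacing the aryl group with ethyl gave an at least 190-fold higher number from compound 1 to compound 3 (2.28 log units; beyond the scatter) and an at least 1000-fold higher number from compound 2 to compound 3 (3.00 log units; beyond the scatter). Between the two aryl-bearing compounds the change of substituent gave a 5.2-fold lower number from compound 1 to compound 2 (0.72 log units; beyond the scatter). Compound 4 carries a methoxy substituent on its aryl ring, as compound 1 does, here para to a large group, so compound 1 is the nearer reference. Restoring an aryl group is expected to give an at least 160-fold lower number from compound 3 to compound 4 (2.22 log units; beyond the scatter), a large fall in the number. For compound 4 the expected value in this assay is 30 nM, with a range from 8 nM to 150 nM.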

Compound 4, half-maximal inhibitory concentration: 263 nM
Compound 4: the middle estimate sits 8.8-fold (0.94 log units) below what was measured; the measured number lies above the stated range.
By their numbers in this assay, from the lowest: compound 2; then compound 1; then compound 4. At a limit, above all of these: compound 3.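

Compound 3 holds only a limit in this assay, so the size of any step from it can be read in one direction only: the limit of > 5000 nM in this assay, at which 1 of the 4 values shown sits. Even so, 4-methoxyphenyl in place of ethyl gives an at least 19-fold lower number from compound 3 to compound 4 (1.27 log units; beyond the scatter), which extends the link between an aryl group at this place and a lower number in this assay to a third aryl-bearing compound. The aryl group alone does not fix the level, however: 4-methoxyphenyl in place of 2-methoxyphenyl gives a 10-fold higher number from compound 1 to compound 4 (1.00 log units; beyond the scatter), and 4-methoxyphenyl in place of 2-fluorophenyl gives a 53-fold higher number from compound 2 to compound 4 (1.72 log units; beyond the scatter), so which substituted aryl group enters matters well beyond the scatter.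

The compounds shown do not settle whether the rise seen with compound 4 follows the methoxy group itself or any group carried at that place on the ring, a question that an unsubstituted phenyl, 4-fluorophenyl or 3-methoxyphenyl group would help to separate. They also leave open how an aryl group bearing an amine or a carboxylic acid would read in this assay.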